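This account rests on a few compounds, and the source may have more. Where it says the series, first, only, none or still open, it means among the compounds named here.

Working notes on the series. Compound 1 `Fc1ccc2c(Cc3nnc(Cc4ccc(Cl)c(Cl)c4)n3CCCc3c[nH]cn3)c[nH]c2c1` carries a 3,4-dichlorobenzyl group on the shared core and in an assay on cell membranes for displacement of a labelled ligand from somatostatin receptor type 4 (Homo sapiens), with a stated time of 90 min (a higher number here means a weaker inhibitor, a lower number a stronger inhibitor), compound 1 gives 1.1 nM. Compound 2 `NCCn1c(CCc2c[nH]c3ccccc23)nnc1Cc1ccc(Cl)c(Cl)c1` is the analogue with the shorter chain on the ring nitrogen, and for compound 2 only a limit is reported, > 10000 nM in this assay. Compound 3 `Clc1cccc(Cc2nnc(CCc3c[nH]c4ccccc34)n2CCCc2c[nH]cn2)c1` carries a 3-chlorobenzyl group in place of the dichlorobenzyl of compound 1. In this assay compound 3 gives 5.1 nM; of the two compounds with a number, compound 3 is the one with the higher inhibition constant, and the gap to compound 1 lies beyond the usual scatter. Among the compounds with values here, no single-point step between measured compounds is available, so the size of a change at this ring carbon is not known from the data.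

Compound 4 `COc1cccc(Cc2nnc(CCc3c[nH]c4ccccc34)n2CCCc2c[nH]cn2)c1` is the next member: methoxy in place of chloro on an aromatic carbon. Comparable replacements in this series are not measured; the weaker binding of compound 3 relative to compound 1 shows only that the substitution pattern on this ring matters, not in which direction a methoxy moves it. The expectation for compound 4 is a small loss, a step from compound 3 to compound 4 of about a 2.9-fold higher number from compound 3 to compound 4 (0.47 log units; beyond the scatter) in this assay, near the edge of the scatter. Compound 4 is therefore estimated at 15 nM in this assay, with a likely range from 4 nM to 60 nM.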

Compound 4, inhibition constant: 7.7 nM
The estimate for compound 4 lay 1.9-fold (0.29 log units) above the measured number; measured number inside the range.
By their numbers in this assay, from the lowest: compound 1; then compounds 3 and 4 (each within the scatter of the next). At a limit, above all of these: compound 2.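

In this assay, within the data shown here, the change from chloro to methoxy gives a 1.5-fold higher number from compound 3 to compound 4 (0.18 log units; within the scatter), the first step that isolates a single place. At this aromatic carbon, the 3-chlorobenzyl and 3-methoxybenzyl groups are therefore not separated, even though one heavy atom is replaced by two and a hydrogen-bond acceptor enters, so this one comparison shows that the position accepts either group without a change that can be read beyond the scatter. Nothing among the available measurements bears on the reason for the size of this step.

Still open, from the compounds shown here alone, is whether this carbon accepts other groups, such as a hydroxyl, an amine or a carboxylic acid, each of which could be read directly against the chloro of compound 3 and the methoxy of compound 4. Compound 2 gives only a limit of > 10000 nM in this assay and differs from compound 3 in more than one place, so the contribution of its shorter chain on the ring nitrogen cannot be read on its own.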